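The source may report more compounds than this note shows. Statements on the series, on what has been measured and on what is new or still open speak of the compounds shown alone.

Measured so far:
compound 1 `COc1ncnc2c1c(-c1ccccc1)cn2[C@@H]1O[C@H](CO)[C@@H](O)[C@H]1O`: > 20000 nM
compound 2 `CSc1ncnc2c1c(-c1ccsc1)cn2[C@@H]1O[C@H](CO)[C@@H](O)[C@H]1O`: > 20000 nM

Both entries come from a functional assay on A549 cells (Homo sapiens), read by MTT assay, with a stated time of 72 h (on this read-out lower numbers stand for stronger inhibition and higher numbers for weaker inhibition), and neither is a number: each is a limit of the assay. Compound 2 therefore stands only at its limit of > 20000 nM, with no measured potency to place it. Taken together, the evidence amounts to the limit of > 20000 nM in this assay, at which 2 of the 2 values shown sit.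

Compound 3 `CSc1ncnc2c1c(-c1ccccc1)cn2[C@@H]1O[C@H](CO)[C@@H](O)[C@H]1O` differs from compound 2 in one place, with phenyl in place of thiophen-3-yl on an aromatic carbon of a five-membered aromatic ring with 1 nitrogen: phenyl in place of thiophen-3-yl on an aromatic carbon. Among the measured compounds shown here, no measured pair isolates this change, so its size cannot be read from the data. Compound 1 already carries phenyl, and compound 1 also sits at a limit, > 20000 nM. On that basis, no step beyond the scatter is expected in this assay, and compound 3 is expected to stay at the limit. The estimated change is a number no higher from compound 2 to compound 3 (the limit leaves the size open).

For compound 3 the expected value is 20000 nM, within an estimated range of 8000 nM to 40000 nM.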

Compound 3, half-maximal inhibitory concentration: > 20000 nM
Compound 3: a limit, no number; the forecaster's own chance of this, stated with the estimate: 80%; the middle value sits exactly at the limit.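

In this assay compound 3 gives > 20000 nM, which is a limit and not a number. With limits at both ends, neither the step from compound 2 to compound 3 nor the step from compound 1 to compound 3 can be read. The compounds shown leave open what actual values these three compounds have in this assay, and whether thiophen-3-yl or phenyl, or methoxy or methylsulfanyl, makes any difference.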